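Extending the Alkyl Chain on a Shared Core

The source may report more compounds than this note shows. Statements on the series, on what has been measured and on what is new or still open speak of the compounds shown alone.

Compound 2 `CCCCc1ccc(Nc2nc3nonc3nc2O)cc1` carries a butyl group on an aromatic carbon of the shared core. Among the measured compounds shown here, in an assay on mitochondria from L6 cells (Rattus norvegicus) for activation, with a stated time of 90 min (a higher number here means that more compound is needed for the effect, a lower number that less compound is needed), compound 2 gives 2100 nM, the lower end of the two numbers in hand, though the only other compound, compound 1 `CCCCOc1ccc(Nc2nc3nonc3nc2O)cc1`, which gives 3700 nM in this assay, lies within the scatter of it: a 1.8-fold lower number from compound 1 to compound 2 (0.25 log units; within the scatter). Compound 3 `CCCCCc1ccc(Nc2nc3nonc3nc2O)cc1` differs from compound 2 in one place: methyl in place of hydrogen on a saturated chain carbon, four bonds along the chain from an aromatic carbon. For the measured compounds named here, no measured step concerns the length of this chain; the single step in hand exchanges butoxy for butyl and is itself within the scatter, so it offers no direct guide to the new change. The expected step in this assay is therefore small and reads a 1.2-fold lower number from compound 2 to compound 3 (0.07 log units; within the scatter). Compound 3 is accordingly estimated at 1800 nM, with a range from 700 nM to 4500 nM.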

Compound 3, half-maximal effective concentration: 2400 nM
Compound 3: middle estimate off by 1.3-fold (0.12 log units), on the low side; measured number inside the range.
By their numbers in this assay, from the lowest: compounds 2, 3 and 1 (each within the scatter of the next).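

In this assay the added methyl on a saturated chain carbon, four bonds along the chain from an aromatic carbon, gives a 1.1-fold higher number from compound 2 to compound 3 (0.06 log units; within the scatter) and so does not separate the pentyl chain from the butyl chain. The exchange of butoxy for pentyl on an aromatic carbon gives a 1.5-fold lower number from compound 1 to compound 3 (0.19 log units; within the scatter) and, like the exchange of butoxy for butyl, leaves these groups indistinguishable in this read-out. No available evidence bears on these results.

The compounds shown leave open whether a longer chain, such as hexyl or octyl, or a chain ending in an amine or a carboxylic acid, would move the number beyond the scatter. They also leave open what a branched chain or a cyclohexyl group would do in the same place.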